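The source may report more compounds than this note shows. Statements on the series, on what has been measured and on what is new or still open speak of the compounds shown alone.

Working notes on the series: in a functional assay on DU-145 cells (Homo sapiens) for cytotoxicity, read by ELISA, with a stated time of 2 days (on this read-out lower numbers stand for stronger inhibition and higher numbers for weaker inhibition), compound 1 `Oc1cccc(-c2cc(-c3ccccc3)cc(-c3ccsc3)n2)c1` gives 11700 nM and compound 2 `Oc1cccc(-c2cc(-c3ccccc3)cc(-c3ccco3)n2)c1` gives 14400 nM, so compound 2 stands within the scatter of compound 1, the only other number available. Compound 3 `Oc1cccc(-c2cc(-c3ccccc3)cc(-c3ccncc3)n2)c1` is next, with pyridin-4-yl in place of furan-2-yl on an aromatic carbon. Going by the values given here, one measured step bears on this place in the structure, and it joins two five-membered aromatic rings. No six-membered aromatic ring has been measured there, so the evidence is indirect. With only a 1.2-fold higher number from compound 1 to compound 2 (0.09 log units; within the scatter) to go on, no step beyond the scatter is expected in this assay, and no direction is favoured. The expected step is a 1.2-fold lower number from compound 2 to compound 3 (0.08 log units; within the scatter). Compound 3 is estimated at 12000 nM, with an expected range of 4000 nM to 35000 nM.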

Compound 3, half-maximal inhibitory concentration: 19200 nM
The estimate for compound 3 lay 1.6-fold (0.20 log units) below the measured number, and the stated range covers the measured number.
By their numbers in this assay, from the lowest: compounds 1, 2 and 3 (each within the scatter of the next).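

The pyridin-4-yl compound brings the first six-membered aromatic ring to this aromatic carbon, next to the ring nitrogen, and in this assay the change stays within the scatter (a 1.3-fold higher number from compound 2 to compound 3 (0.12 log units; within the scatter); a 1.6-fold higher number from compound 1 to compound 3 (0.22 log units; within the scatter)). Across thiophen-3-yl, furan-2-yl and pyridin-4-yl, neither ring size nor the identity of the hetero atom separates the compounds beyond the scatter in this assay. Nothing at hand accounts for these numbers.

On these data alone, all three groups at this place are aromatic rings with one hetero atom, so it remains open whether an amine, a carboxylic acid or a longer chain there would give a step beyond the scatter. As far as these compounds go, the 3-hydroxyphenyl and phenyl groups are shared by all three compounds, so what changes at those places would do also remains open.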